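From 1-methylpiperidin-3-yl to 1-methylpiperidin-4-yl in compound 3

This account rests on a few compounds, and the source may have more. Where it says the series, first, only, none or still open, it means among the compounds named here.

In an ADME assay on microsomes from liver (Mus musculus) for metabolic stability, read by LC-MS, using NADPH, with stated times of 15 min and 60 min, tested at 4.6 uM (on this read-out lower numbers stand for a less stable compound and higher numbers for a more stable compound), compound 1 (`CC(C)CNC(=O)n1c(=O)oc2cc(C3CCCN(C)C3)ccc21`) gives 70% and compound 2 (`CN1CCC(c2cc3oc(=O)n(C(=O)NCCCCc4ccccc4)c3cc2F)CC1`) gives 70% as well, so the two stand level. Compound 3 (`CC(C)CNC(=O)n1c(=O)oc2cc(C3CCN(C)CC3)ccc21`) has not yet been measured. It differs from compound 1 on an aromatic carbon, where 1-methylpiperidin-4-yl stands in place of 1-methylpiperidin-3-yl (1-methylpiperidin-4-yl in place of 1-methylpiperidin-3-yl on an aromatic carbon). Within the data shown here, no measured pair shows this change, so the expected step (a number 2 percentage points lower from compound 1 to compound 3 (within the scatter)) in this assay is none beyond the scatter. Compound 3 is expected at 68% (estimated range 50% to 84%).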

Compound 3, percent of the compound remaining: 80%
Compound 3: the middle estimate sits 12 percentage points below what was measured; measured number inside the range.
By their numbers in this assay, from the lowest: compounds 1, 2 and 3 (each within the scatter of the next).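

Among these compounds, replacing 1-methylpiperidin-3-yl with 1-methylpiperidin-4-yl on the aromatic carbon gives the first direct reading of this change: in this assay the step is a number 10 percentage points higher from compound 1 to compound 3 (within the scatter). On the core of compound 1, the two attachments of the same ring therefore cannot be told apart on this read-out. Nothing at hand offers an explanation for this result. The compounds shown leave open whether a piperidin-4-yl without the methyl group, or a pyrrolidine ring, at this place would stay within the scatter of compound 3.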